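A few compounds are considered here, and "the series" means these few. Any claim that something is new, unique, unknown or untested is made for them only; others in the source may bear on it.

Of the compounds shown here, three built on one shared core have been tested in a functional assay on the whole organism (strain Kunming) for inhibition, with Mus musculus as the target, with a stated time of 1 h, at a dose of 40 mg/kg by the oral route; on this read-out lower numbers stand for less inhibition and higher numbers for more inhibition at the one dose given (going by the name of the read-out). Compound 1 `O=C(/C=C/c1ccccc1)c1ccc(N2CCN(c3ccccc3F)CC2)cc1` gives 0.57% in this assay, compound 2 `O=C(/C=C/c1ccccc1)c1ccc(N2CCN(c3cccc(Cl)c3)CC2)cc1` gives 14.1%, and compound 3 `O=C(/C=C/c1ccccc1)c1ccc(N2CCN(c3ccccc3Cl)CC2)cc1` gives 4.71%. On the bare numbers compound 3 stands second highest of the three, but the steps of a number 4.1 percentage points higher from compound 1 to compound 3 (within the scatter) and a number 9.4 percentage points lower from compound 2 to compound 3 (within the scatter) both lie within the scatter, so no real order between these three can be read from them. Within the data shown here, only the step of a number 13.5 percentage points higher from compound 1 to compound 2 (beyond the scatter) lies beyond the scatter, and even that is modest.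

Compound 4 `O=C(/C=C/c1ccccc1)c1ccc(N2CCN(S(=O)(=O)c3ccc(Cl)cc3)CC2)cc1` has not yet been measured. It differs from compound 3 in one place: (4-chlorophenyl)sulfonyl in place of 2-chlorophenyl on an amine nitrogen in a ring. Among the measured compounds shown here, none of the measured steps touches this kind of change; they only exchange 2-fluorophenyl, 3-chlorophenyl and 2-chlorophenyl among themselves on the ring nitrogen, and all three measured numbers are low. There is therefore no basis for expecting a step beyond the scatter in either direction. Compound 4 is expected to give 8% in this assay, within a range from 0% to 25%. The expected step is a number 3.3 percentage points higher from compound 3 to compound 4 (within the scatter).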

Compound 4, a percentage reported as inhibition, in the whole organism at one dose (the size of the read-out at that dose, not a potency): 46.8%
Compound 4: middle estimate off by 38.8 percentage points, on the low side, and the stated range ends below it.
By their numbers in this assay, from the lowest: compounds 1, 3 and 2 (each within the scatter of the next, the first and the last beyond it); then compound 4.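

Putting (4-chlorophenyl)sulfonyl on the ring nitrogen changes this assay far more than the exchanges among the directly attached phenyl groups did: the result is a number 42.1 percentage points higher from compound 3 to compound 4 (beyond the scatter), and likewise a number 32.7 percentage points higher from compound 2 to compound 4 (beyond the scatter) and a number 46.2 percentage points higher from compound 1 to compound 4 (beyond the scatter). All three steps are large, so this position is not limited to the low numbers of the first compounds, and the kind of group on this nitrogen can strongly affect the read-out. No measurement shown here explains why the step is so large.

The change brings in a sulfonyl link and a 4-chlorophenyl group together, so the compounds shown do not tell which part carries the step. As far as these compounds go, whether a benzoyl group or a methylsulfonyl group on the same nitrogen would give a similar number also remains open.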